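The source may hold more compounds than are shown below. What is called first, only, known or untested is meant among the compounds shown, and "the series" means these compounds.

Of the compounds shown here, two have been measured in an assay on isolated protein for inhibition of retinal dehydrogenase 2 (Homo sapiens); a higher number here means a weaker inhibitor, a lower number a stronger inhibitor. Compound 1, `CC(C)C(Sc1nc2c(cnn2C)c(=O)n1-c1ccccc1)c1ccccc1`, gives 300 nM in this assay. Compound 2, `Cn1ncc2c(=O)n(-c3ccccc3)c(OCc3cccc(F)c3)nc21`, gives 3700 nM in this assay. Of these two numbers, compound 1 has the lower one, and the gap to compound 2 is beyond the usual scatter of such measurements, so compound 1 is the stronger inhibitor of the pair; compound 2 differs from compound 1 in more than one place, so nothing can be said about which of its differences matters.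

Compound 3, `CC(Sc1nc2c(cnn2C)c(=O)n1-c1ccccc1)c1ccccc1`, shares the core of compound 1 and differs from it in one place: methyl in place of isopropyl on a saturated chain carbon bound to an aromatic carbon and a sulfur. Among the measured compounds shown here, no measured pair shows the effect of such a change, so the direction of the step cannot be taken from the data. Since only a small part of the side chain is removed and no donor or acceptor is gained or lost, the step from compound 1 to compound 3 in this assay is expected to be modest, most likely toward a somewhat higher number, with a 2.0-fold higher number from compound 1 to compound 3 (0.30 log units; within the scatter) as the estimated step. Compound 3 is therefore expected to give about 600 nM in this assay, within a range of 200 nM to 2500 nM.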

Compound 3, half-maximal inhibitory concentration: 110 nM
For compound 3 the middle estimate is 5.5-fold (0.74 log units) above the measured one; measured number outside the range, below it.
By their numbers in this assay, from the lowest: compound 3; then compound 1; then compound 2.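

In this assay, replacing isopropyl with methyl on the saturated chain carbon bound to an aromatic carbon and a sulfur gives a 2.7-fold lower number from compound 1 to compound 3 (0.44 log units; beyond the scatter), so compound 3 is a stronger inhibitor than compound 1. Among the compounds shown here, this is the first comparison that changes only one place, and it shows that this position affects inhibition and that the isopropyl group is not needed to reach the potency of compound 1. The change removes carbon atoms only, with no hydrogen-bond donor, hydrogen-bond acceptor or charge entering or leaving, but no measurement shown explains why the shorter group gives the lower number.

For the compounds shown here, with only two groups compared at this position, no trend with group size can be claimed, and it remains open whether an ethyl group would give a number between those of compound 3 and compound 1. On these data alone, it is also open whether a plain hydrogen on that carbon would lower the number further, or whether an amine or a carboxylic acid would be tolerated there.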